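Bromo for fluoro on the shared core: a small step

The compounds below may be only part of what the source reports. "The series", "measured", "known", "first", "only" and "open" are said of these compounds alone.

a functional assay on NCI-H292 cells (Homo sapiens) for cytotoxicity, read by MTT assay, with a stated time of 72 h, tested at 2.5 ug/mL (a lower number here means less inhibition of growth, a higher number more inhibition of growth at the concentration tested), is the only measurement available for this series. Compound 1 `O=C1NC(=S)/C(=C/c2cccc(Cl)c2)S1` gives 11.2% in this assay, and compound 2 `O=C1NC(=S)/C(=C/c2cccc(F)c2)S1` gives 3.43%. The two numbers lie within the scatter of each other, so compound 2 stands alongside compound 1 and the pair cannot be told apart on these figures. Compound 3 `O=C1NC(=S)/C(=C/c2cccc(Br)c2)S1` differs from compound 2 by a single change: bromo in place of fluoro on an aromatic carbon. Within the data shown here, the one measured step that bears on this is the halogen exchange at the same aromatic carbon, a number 7.8 percentage points lower from compound 1 to compound 2 (within the scatter), which stayed inside the scatter. Since replacing fluoro by bromo is again a halogen exchange at the same carbon, the expected step is a number 4.6 percentage points higher from compound 2 to compound 3 (within the scatter), meaning nothing beyond the scatter. Compound 3 is therefore estimated at 8%, with a range from -4% to 20%.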

Compound 3, percent growth inhibition at one concentration: 11.1%
The estimate for compound 3 lay 3.1 percentage points below the measured number; measured number inside the range.
By their numbers in this assay, from the lowest: compounds 2, 3 and 1 (each within the scatter of the next).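

With bromo in place, all three halogens shown have been compared at this same aromatic carbon of the shared core. In this assay the exchange of fluoro for bromo gives a number 7.7 percentage points higher from compound 2 to compound 3 (within the scatter) and the exchange of chloro for bromo gives a number 0.1 percentage points lower from compound 1 to compound 3 (within the scatter) at that carbon. Fluoro, chloro and bromo therefore cannot be told apart at this position on these figures, and no measurement at hand offers an explanation for this result.

From the compounds shown here alone, it remains open whether a group other than a halogen, such as an amine, a carboxylic acid or a longer chain, would give a different number at this carbon. Going by these compounds, it also remains open whether a halogen at another carbon of the six-membered aromatic ring would behave the same way.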